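Amino for methoxy on the shared core

The compounds below may be only part of what the source reports. "The series", "measured", "known", "first", "only" and "open" are said of these compounds alone.

In an ADME assay on Vero cells (Chlorocebus sabaeus) for cytotoxicity, with a stated time of 72 h (on this read-out higher numbers stand for weaker inhibition and lower numbers for stronger inhibition), compound 2 (`CCOC(=O)c1cc(/C=C/c2cccc(OC)c2)on1`) gives > 128000 nM as a limit, not a number. Compound 1 (`CCOC(=O)c1cc(/C=C/c2cccc(C(F)(F)F)c2)on1`) likewise gives > 128000 nM as a limit. Together they mark the limit of > 128000 nM in this assay, at which 2 of the 2 values shown sit, and nothing finer. Among the compounds with values here, the one measured step, a step that the two limits leave unreadable from compound 1 to compound 2, offers no size to carry forward. Compound 3 (`CCOC(=O)c1cc(/C=C/c2cccc(N)c2)on1`) brings amino in place of methoxy on an aromatic carbon as its change, amino in place of methoxy on an aromatic carbon. No step beyond the scatter is expected, and another limit is quite likely. In this assay the expected step is an at least 1.1-fold lower number from compound 2 to compound 3 (0.06 log units; that floor lies within the scatter) and no more. Compound 3 is estimated at 110000 nM with an expected range from 45000 nM to 128000 nM for that estimate.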

Compound 3, half-maximal inhibitory concentration: > 128000 nM
Compound 3: no number, only a limit; the forecaster's own chance of this, stated with the estimate: 65%; at least 1.1-fold (0.06 log units) between middle value and limit.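

Within the data shown here, no step among compound 1, compound 2 and compound 3 can be read, since all three give only a limit and no number: the limit of > 128000 nM in this assay, at which 3 of the 3 values shown sit. The compounds shown leave open whether trifluoromethyl, methoxy and amino on the shared core differ at all on this read-out.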